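Series notes: carboxy in place of dimethylsulfamoyl

The source may hold more compounds than are shown below. What is called first, only, known or untested is meant among the compounds shown, and "the series" means these compounds.

Compound 3 `CCCCCCCCc1ccc(OCC(=O)Cn2nnnc2-c2cccc(S(=O)(=O)N(C)C)c2)cc1` in an ADME assay on S9 fraction from liver (Rattus norvegicus) for metabolic stability, read by LC-MS, using NADPH, with a stated time of 30 min (on this read-out lower numbers stand for a less stable compound and higher numbers for a more stable compound), gives 24%, at the low end of the three numbers recorded. Compound 1 `CCCCCCCCc1ccc(OCC(=O)Cn2nnc(-c3ccccc3Cl)n2)cc1` gives 28%, which lies within the scatter of compound 3. Going by the values given here, compound 2 `CCCCCCCCc1ccc(OCC(=O)Cn2nnnc2-c2ccc(S(=O)(=O)N(C)C)cc2)cc1` gives 40%; the step of a number 16 percentage points lower from compound 2 to compound 3 (beyond the scatter) is the only measured step that goes beyond the scatter.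

Compound 4 `CCCCCCCCc1ccc(OCC(=O)Cn2nnnc2-c2cccc(C(=O)O)c2)cc1` differs from compound 3 in one place: carboxy in place of dimethylsulfamoyl on an aromatic carbon. Among the compounds with values here, no measured step exchanges a dimethylsulfamoyl for a carboxy. Within the data shown here, the one measured step, a number 16 percentage points lower from compound 2 to compound 3 (beyond the scatter), moves the dimethylsulfamoyl from one position to another and does not bear directly on the new group. The expectation therefore rests on compound 3 alone, with the range widened for an untested change. Compound 4 is estimated at 30%, with a range from 12% to 52%. The expected step of a number 6 percentage points higher from compound 3 to compound 4 (within the scatter) is none beyond the scatter, in either direction.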

Compound 4, percent of the compound remaining: < 5%
Compound 4 was reported as a limit; the forecaster's own chance of this, stated with the estimate: 0%; middle value at least 25 percentage points from the limit.
By their numbers in this assay, from the lowest: compounds 3 and 1 (each within the scatter of the next); then compound 2. At a limit, below all of these: compound 4.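

Carboxy in place of dimethylsulfamoyl on this aromatic carbon gives a number at least 19 percentage points lower from compound 3 to compound 4 (beyond the scatter), so in this assay the identity of the group at this position can move the read-out beyond the scatter, whereas the earlier step showed only the effect of moving the dimethylsulfamoyl. The change from 4-(dimethylsulfamoyl)phenyl to 3-carboxyphenyl gives a number at least 35 percentage points lower from compound 2 to compound 4 (beyond the scatter), which is a large step. The value of compound 4 is a limit of the assay and not a number: the limit of < 5% in this assay, at which 1 of the 4 values shown sits.

An ester or an amide on this aromatic carbon would help show whether the read-out follows carboxy itself or extends to other replacements of dimethylsulfamoyl. On these data alone, whether the same change holds with a chain shorter than octyl on the core also remains open.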